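Hydroxamic acid in place of an inactive peroxide acid

A few compounds are considered here, and "the series" means these few. Any claim that something is new, unique, unknown or untested is made for them only; others in the source may bear on it.

Three compounds sharing one core were tested in a functional assay on A549 cells (Homo sapiens) for cytotoxicity, read by MTT assay, with a stated time of 48 h; a higher number here means a weaker inhibitor, a lower number a stronger inhibitor. Compound 1 `O=C(N[C@H]1CC[C@]2(CC1)OO[C@]1(O2)C2CC3CC(C2)CC1C3)c1ccc(O)c(O)c1` returned only a limit of the assay, > 50000 nM. Compound 3 `O=C(N[C@H]1CC[C@]2(CC1)OC[C@]1(O2)C2CC3CC(C2)CC1C3)c1ccc(O)c(O)c1` likewise gave only a limit, > 50000 nM. Compound 2 `O=C(O)[C@H]1CC[C@@]2(CC1)OC[C@]1(OO2)C2CC3CC(C2)CC1C3`, the acid, also reached no number, and its result in this assay is the limit > 100000 nM. So compound 2 sits at the limit of > 100000 nM in this assay, at which 1 of the 3 values shown sits, while the two other compounds sit at the limit of > 50000 nM in this assay, at which 2 of the 3 values shown sit; none of the three is separated from another beyond the usual scatter.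

Compound 4 `O=C(NO)[C@H]1CC[C@@]2(CC1)OC[C@]1(OO2)C2CC3CC(C2)CC1C3` differs from compound 2 by one change (hydroxyamino in place of hydroxy on a carbonyl carbon). Among the compounds with values here, no two measured compounds differ in a single place, so no measured step guides this change. In this assay the estimated step is an at least 1.2-fold lower number from compound 2 to compound 4 (0.09 log units; that floor lies within the scatter), expected to lie within the scatter, with a good chance that only a limit is reported again. Compound 4 is therefore expected to give about 80000 nM, within a range from 20000 nM to 200000 nM.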

Compound 4, half-maximal inhibitory concentration: > 50000 nM
Compound 4: no number, only a limit (the forecaster's own chance of this, stated with the estimate: 70%); the middle value is on the limit's open side.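

In this assay compound 4 gives only a limit, > 50000 nM. Compound 2 likewise gives only a limit, > 100000 nM. Within the data shown here, no step between compound 2 and compound 4 can therefore be read. The compounds shown leave open whether hydroxyamino in place of hydroxy on a carbonyl carbon changes the result in this assay at all.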